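Methoxy for methyl at a second place on the anilide

The source may report more compounds than this note shows. Statements on the series, on what has been measured and on what is new or still open speak of the compounds shown alone.

Three compounds share one core and differ only in the group on the amide-type nitrogen. Compound 1 `Cc1ccc(NC(=O)c2c(O)c3cccnc3n(-c3ccccc3)c2=O)cc1` gives 2.2% in a functional assay on the whole organism for inhibition, with Rattus norvegicus as the target, read by cytopathic effect and paw edema, at a dose of 100 mg/kg by the oral route; a higher number here means more inhibition at the dose given (going by the name of the read-out), a lower number less inhibition. Compound 2 `COc1ccc(NC(=O)c2c(O)c3cccnc3n(-c3ccccc3)c2=O)cc1` is reached from compound 1 by methoxy in place of methyl on an aromatic carbon. In this assay compound 2 gives -1.9%, a step of a number 4.1 percentage points lower from compound 1 to compound 2 (within the scatter). Compound 3 `Cc1ccccc1NC(=O)c1c(O)c2cccnc2n(-c2ccccc2)c1=O` gives 9.8% in this assay; its core differs from that of compound 1 by 2-methylphenyl in place of 4-methylphenyl on an amide-type nitrogen. Compound 4 `COc1ccccc1NC(=O)c1c(O)c2cccnc2n(-c2ccccc2)c1=O` is not yet measured and arises from compound 3 by methoxy in place of methyl on an aromatic carbon. This is the same kind of change as that from compound 1 to compound 2, yet the place differs: there the group sits para to a large group, here ortho to a large group. The step from compound 3 to compound 4 is expected to be a number 4.3 percentage points lower from compound 3 to compound 4 (within the scatter), small like the earlier one, because the earlier step was a number 4.1 percentage points lower from compound 1 to compound 2 (within the scatter). Compound 4 is therefore expected to give 5.5%, likely between -8% and 18%.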

Compound 4, a percentage reported as inhibition, in the whole organism at one dose (the size of the read-out at that dose, not a potency): -10.1%
Estimate against measurement, compound 4: 15.6 percentage points above; the whole stated range lies above it.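

In this assay, methoxy in place of methyl does not give a step of the same size on the two cores: the same change on two cores in this assay, a number 4.1 percentage points lower (within the scatter) from compound 1 to compound 2 and a number 19.9 percentage points lower (beyond the scatter) from compound 3 to compound 4, 15.8 percentage points apart, beyond the scatter of two such steps

With the group ortho to a large group, the change gives a number 19.9 percentage points lower from compound 3 to compound 4 (beyond the scatter), while 2-methoxyphenyl in place of 4-methoxyphenyl gives a number 8.2 percentage points lower from compound 2 to compound 4 (within the scatter), and 2-methoxyphenyl in place of 4-methylphenyl gives a number 12.3 percentage points lower from compound 1 to compound 4 (beyond the scatter). So a step seen on one core cannot simply be carried to the other here, yet two pairs of compounds make no general rule and do not show why the steps differ.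

From the compounds shown here alone, it remains open how other groups at this place, such as an amine, a carboxylic acid or a longer chain, would behave on either core.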